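Adding a methyl to compound 3

The source may report more compounds than this note shows. Statements on the series, on what has been measured and on what is new or still open speak of the compounds shown alone.

Measured so far in an ADME assay on microsomes from liver (Rattus norvegicus) for metabolic stability; on this read-out higher numbers stand for a longer-lived compound and lower numbers for a shorter-lived compound 
compound 1 `CN1C(=O)CCc2cc(Nc3cc4c(cn3)ncn4CC3CC3)ccc21` gives 0.417 h
compound 2 `CN1C(=O)COc2cc(Nc3cc4c(cc3OC(F)(F)F)ncn4CC3CC3)cnc21` gives 0.55 h
compound 3 `CN1C(=O)COc2cc(Nc3cc4c(cc3F)ncn4CC3CC3)cnc21` gives 0.283 h

Compound 3 at 0.283 h sits within the scatter of both compound 1 and compound 2. Compound 4 `Cc1c(F)c(Nc2cnc3c(c2)OCC(=O)N3C)cc2c1ncn2CC1CC1` carries methyl in place of hydrogen on an aromatic carbon, ortho to a fluoro group (methyl in place of hydrogen on an aromatic carbon). Within the data shown here, the one measured step (a 1.9-fold lower number from compound 2 to compound 3 (0.29 log units; within the scatter)) exchanges trifluoromethoxy for fluoro, stays within the scatter and involves no methyl. Among the measured compounds shown here, it therefore gives only weak guidance, and no measured step adds a methyl. In this assay no shift beyond the scatter is expected, and neither direction is favoured. The expected step is small (a 1.1-fold higher number from compound 3 to compound 4 (0.03 log units; within the scatter)). For compound 4 the estimated value is 0.3 h (0.15 h to 0.6 h).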

Compound 4, half-life: 0.917 h
The estimate for compound 4 lay 3.1-fold (0.49 log units) below the measured number, outside the stated range (above it).
By their numbers in this assay, from the lowest: compounds 3, 1, 2 and 4 (each within the scatter of the next, the first and the last beyond it).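

Methyl in place of hydrogen on an aromatic carbon, ortho to a fluoro group, gives the only step beyond the scatter shown so far in this assay (a 3.2-fold higher number from compound 3 to compound 4 (0.51 log units; beyond the scatter)). The one earlier step, at a different place, stayed within the scatter, so this aromatic carbon is the one place shown to move the half-life. No measurement bears on the cause of this rise.

On these data alone, whether an ethyl or a methoxy group on this carbon would give a similar rise remains open. As far as these compounds go, the methyl step also rests on a single pair, so its size without the fluoro group is unknown.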